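A few compounds are considered here, and "the series" means these few. Any claim that something is new, unique, unknown or untested is made for them only; others in the source may bear on it.

Measured in an assay on HL-60 cells for agonist activity at vitamin D3 receptor (Homo sapiens), read by microscopy, with a stated time of 96 h; a lower number here means that less compound is needed, a higher number that more compound is needed for the effect:
Compound 1 `CCN(CC)CCCNC(=O)c1ccc(C(CC)(CC)c2ccc(OCC(=O)C(C)(C)C)c(C)c2)n1CC` gives 22 nM.
Compound 2 `CCn1c(C(=O)N(C)c2ccccc2)ccc1C(CC)(CC)c1ccc(OCC(=O)C(C)(C)C)c(C)c1` gives 18500 nM.
Compound 3 `C#CC(C)OC(=O)c1ccc(C(CC)(CC)c2ccc(OCC(=O)C(C)(C)C)c(C)c2)n1CC` gives 210 nM.

Compound 3 stands second of the three in this assay, separated from compound 1 by a 9.5-fold higher number from compound 1 to compound 3 (0.98 log units; beyond the scatter) and from compound 2 by an 88-fold lower number from compound 2 to compound 3 (1.94 log units; beyond the scatter). Compound 4 `C#CCCOC(=O)c1ccc(C(CC)(CC)c2ccc(OCC(=O)C(C)(C)C)c(C)c2)n1CC` is the next candidate; the change is but-3-yn-1-yl in place of 1-methylprop-2-yn-1-yl on an oxygen next to a carbonyl group. Among the compounds with values here, the two steps that reach compound 3, a 9.5-fold higher number from compound 1 to compound 3 (0.98 log units; beyond the scatter) and an 88-fold lower number from compound 2 to compound 3 (1.94 log units; beyond the scatter), exchange the whole group on the carbonyl for another kind of group and were large, but none of the measured steps rearranges the same atoms within an alkynyl ester. With nothing of that kind to rest on, the expected step is one not beyond the scatter, no change at the digits printed from compound 3 to compound 4 (within the scatter). Compound 4 is therefore estimated at 210 nM, within 70 nM to 700 nM.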

Compound 4, half-maximal effective concentration: 28800 nM
The estimate for compound 4 lay 140-fold (2.14 log units) below the measured number, outside the stated range (above it).
By their numbers in this assay, from the lowest: compound 1; then compound 3; then compounds 2 and 4 (each within the scatter of the next).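

Within the data shown here, on an oxygen next to a carbonyl group, rearranging the alkynyl chain alone matters in this assay: but-3-yn-1-yl in place of 1-methylprop-2-yn-1-yl gives a step (a 140-fold higher number from compound 3 to compound 4 (2.14 log units; beyond the scatter)) of a size earlier seen only on exchanging the whole group. The (but-3-yn-1-yl)oxy group cannot be told from methyl(phenyl)amino (a 1.6-fold higher number from compound 2 to compound 4 (0.19 log units; within the scatter)) and stands far from (3-(diethylamino)propyl)amino (a 1300-fold higher number from compound 1 to compound 4 (3.12 log units; beyond the scatter)). No measurement available gives a reason for the rearrangement step.

Going by these compounds, whether the methyl branch or the chain length carries this step remains open. Prop-2-yn-1-yl and butyl on the same oxygen would help separate the two.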